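Amide versus urea on the anilide carbonyl

The compounds below may be only part of what the source reports. "The series", "measured", "known", "first", "only" and "open" are said of these compounds alone.

Three compounds share one core and differ only in the group on the carbonyl carbon that sits on the anilide nitrogen. Compound 1 `COc1cc(-c2nn(-c3cccc(NC(=O)c4cccc(C(F)(F)F)c4)c3)cc2-c2ccncc2)ccc1Cl` carries 3-(trifluoromethyl)phenyl there, and in a functional assay on SF-268 cells (Homo sapiens) for inhibition, read by sulforhodamine B assay, with a stated time of 48 h (a lower number here means that less compound is tolerated, a higher number that more compound is tolerated), compound 1 reaches only the limit of > 50000 nM. Compound 2 `COc1cc(-c2nn(-c3cccc(NC(=O)Nc4ccc(Cl)c(Cl)c4)c3)cc2-c2ccncc2)ccc1Cl`, the urea bearing (3,4-dichlorophenyl)amino, likewise stops at the limit of > 50000 nM in this assay. Going by the values given here, compound 3 `COc1cc(-c2nn(-c3cccc(NC(=O)Nc4cccc(C(F)(F)F)c4)c3)cc2-c2ccncc2)ccc1Cl`, the urea bearing (3-(trifluoromethyl)phenyl)amino, gives 50000 nM in this assay, the only plain number among the three. The measured steps are a step that the two limits leave unreadable from compound 1 to compound 2, a number no higher from compound 1 to compound 3 (the limit leaves the size open) and a number no higher from compound 2 to compound 3 (the limit leaves the size open), and none has a readable size, since (the limit of > 50000 nM in this assay, at which 2 of the 3 values shown sit). Compound 4 `COc1cc(-c2nn(-c3cccc(NC(=O)c4ccc(Cl)c(C(F)(F)F)c4)c3)cc2-c2ccncc2)ccc1Cl` has not been measured; it differs from compound 3 by 4-chloro-3-(trifluoromethyl)phenyl in place of (3-(trifluoromethyl)phenyl)amino on a carbonyl carbon, returning to the amide type of compound 1. The step that bears on it is a number no higher from compound 1 to compound 3 (the limit leaves the size open), with its size left open. Compound 4 is therefore expected to give 50000 nM in this assay, between 25000 nM and 150000 nM, with a fair chance that only a limit is returned. The expected step is no change at the digits printed from compound 3 to compound 4 (within the scatter).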

Compound 4, concentration lethal to 50% of the cells: > 32500 nM
Compound 4: a limit, no number; the forecaster's own chance of this, stated with the estimate: 70%; the middle value lies beyond the limit too.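

Going by these compounds alone, compound 4 returns only a limit, so no step linking it to compound 1, compound 2 or compound 3 can be read: the limit of > 32500 nM in this assay, at which 1 of the 4 values shown sits. The compounds shown leave open whether chloro in place of hydrogen, the one difference between compound 1 and compound 4, changes the number in this assay at all.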